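Removing a Hydroxy Group from the Pyridyl Alkyne Arm

The source may report more compounds than this note shows. Statements on the series, on what has been measured and on what is new or still open speak of the compounds shown alone.

Measured compounds:
Compound 1, `Cc1ccc(-n2nccn2)c(C(=O)N2C[C@H](C#Cc3cc(CO)ccn3)CC[C@H]2C)c1`: in a functional assay on isolated protein for antagonist activity at Orexin/Hypocretin receptor type 1 (Homo sapiens), read by FLIPR and calcium flux (on this read-out higher numbers stand for weaker inhibition and lower numbers for stronger inhibition), compound 1 gives "not determined" (no result reported).
Compound 2, `Cc1ccc(-n2nccn2)c(C(=O)N2C[C@H](C#Cc3cnccc3O)CC[C@H]2C)c1`: 3880 nM.

For the measured compounds named here, compound 2 provides the only number here; compound 1 carries no result, so there is nothing to set compound 2 against within this small group, and it is simply a weak inhibitor by its own value. Compound 3, `Cc1ccc(-n2nccn2)c(C(=O)N2C[C@H](C#Cc3cccnc3)CC[C@H]2C)c1`, has not been measured. It differs from compound 2 in a single place: hydrogen in place of hydroxy on an aromatic carbon. Going by the values given here, no step between measured compounds exists to calibrate how much the loss of a hydroxy on an aromatic carbon shifts this read-out. Since compound 2 gives 3880 nM, the result for compound 3 is expected to stay in the same weak range, with a step of a 1.6-fold lower number from compound 2 to compound 3 (0.19 log units; within the scatter) that is expected to be modest and could fall in either direction. Compound 3 is therefore estimated at 2500 nM, within a range from 500 nM to 12000 nM.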

Compound 3, half-maximal inhibitory concentration: 83 nM
Compound 3: middle estimate off by 30-fold (1.48 log units), on the high side; the whole stated range lies above it.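

Replacing the hydroxy with hydrogen, which turns 4-hydroxypyridin-3-yl into pyridin-3-yl, gives in this assay a 47-fold lower number from compound 2 to compound 3 (1.67 log units; beyond the scatter) and so separates a weak inhibitor from a much stronger one. Compound 2 alone could not show that this aromatic carbon, ortho to a large group and opposite the ring nitrogen, matters so much, yet the change removes only one heavy atom, an oxygen. Nothing available here explains why the read-out moves this far.

The compounds shown leave open whether only hydroxy gives this weak result, since an amine, a methoxy group or a fluorine on the same carbon does not appear among them. Compound 1 has no result, so it adds nothing on the hydroxymethyl group it carries.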